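Bromo Added to the Weaker Dimethylamino Analogue

A few compounds are considered here, and "the series" means these few. Any claim that something is new, unique, unknown or untested is made for them only; others in the source may bear on it.

Compound 1, `COc1ccc(C2CC(c3ccccc3)=NN2C2=NC(=O)/C(=C3\C(=O)Nc4ccc(Br)cc43)S2)cc1`: 480 nM
Compound 2, `CN(C)c1ccc(C2CC(c3ccccc3)=NN2C2=NC(=O)/C(=C3\C(=O)Nc4ccccc43)S2)cc1`: 20300 nM

Of the compounds shown here, two on a shared core have been measured in a functional assay on cells (Cancer cell lines, Homo sapiens) for cytotoxicity, read by sulforhodamine B assay, with a stated time of 48 h; a lower number here means a stronger inhibitor of growth, a higher number a weaker inhibitor of growth. Compound 1 gives 480 nM in this assay. Compound 2 gives 20300 nM in this assay, the highest number of the two, and its gap to compound 1 lies well beyond the scatter. Within the data shown here, the two differ in more than one place, so no single step between them can be read off: compound 1 carries a methoxy group on its pendant phenyl and a bromo on the fused ring system, while compound 2 carries a dimethylamino group and no bromo.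

Compound 3, `CN(C)c1ccc(C2CC(c3ccccc3)=NN2C2=NC(=O)/C(=C3\C(=O)Nc4ccc(Br)cc43)S2)cc1`, has not yet been measured. It differs from compound 2 by bromo in place of hydrogen on an aromatic carbon, placed meta to a fused ring and para to a fused ring, and so combines the dimethylamino group of compound 2 with the bromo of compound 1. Since the lower number in this assay belongs to compound 1, which gives 480 nM, a move toward lower numbers is expected, though its size is uncertain. The expected step is a 5.1-fold lower number from compound 2 to compound 3 (0.71 log units; beyond the scatter). Compound 3 is estimated at 4000 nM, within a range of 800 nM to 20000 nM.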

Compound 3, concentration for total growth inhibition: 510 nM
Compound 3: middle estimate off by 7.8-fold (0.89 log units), on the high side; the measured number lies below the stated range.
By their numbers in this assay, from the lowest: compounds 1 and 3 (each within the scatter of the next); then compound 2.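

In this assay, bromo in place of hydrogen on an aromatic carbon, meta to a fused ring and para to a fused ring, gives a 40-fold lower number from compound 2 to compound 3 (1.60 log units; beyond the scatter), a large step from a change of one heavy atom that could not be isolated while only compound 1 and compound 2 stood side by side. With the bromo in place, dimethylamino in place of methoxy on an aromatic carbon gives a 1.1-fold higher number from compound 1 to compound 3 (0.03 log units; within the scatter), which lies within the scatter, so this exchange of groups does not separate compound 1 from compound 3. The dimethylamino group carried by compound 2 therefore does not by itself hold the number high when the bromo is present.

As far as these compounds go, whether chloro, fluoro or a methyl group on the same aromatic carbon would give a step of similar size remains open, as does the number of the methoxy compound without bromo, which would show whether the bromo step holds with methoxy too. No evidence is available that bears on what lies behind the size of the bromo step.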